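Cytotoxicity notes: amidoxime to trifluoromethyl on the chain

A few compounds are considered here, and "the series" means these few. Any claim that something is new, unique, unknown or untested is made for them only; others in the source may bear on it.

Measured compounds:
- compound 1 `N=C(CCCn1c(Cn2c(=O)n(C3CC3)c3ccncc32)cc2cc(Cl)ccc21)NO` — in an ADME assay on HeLa cells (Homo sapiens) for cytotoxicity, read by ATP content, with a stated time of 3 days (on this read-out lower numbers stand for higher toxicity in this test and higher numbers for lower toxicity in this test), compound 1 gives only a limit, > 50000 nM.
- compound 2 `CC(C)CCn1c(Cn2c(=O)n(C3CC3)c3ccncc32)nc2nc(Cl)ccc21` — in this assay compound 2 gives only a limit, > 50000 nM.
- compound 3 `CC(C)(O)CCCn1c(Cn2c(=O)n(C3CC3)c3ccncc32)nc2nc(Cl)ccc21` — in this assay compound 3 gives only a limit, > 50000 nM.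

Compound 1 stands at the limit of the assay, not at a number; the other two values shown are limits as well. Among the measured compounds shown here, the one step between measured compounds, a step that the two limits leave unreadable from compound 2 to compound 3, is therefore unreadable in size, which is the whole of the measured evidence: the limit of > 50000 nM in this assay, at which 3 of the 3 values shown sit.

Compound 4 `O=c1n(Cc2cc3cc(Cl)ccc3n2CCCC(F)(F)F)c2cnccc2n1C1CC1` is the unmeasured member. It differs from compound 1 by a group of 4 heavy atoms (1 carbon, 3 fluorine; no ring) in place of a group of 4 heavy atoms (1 carbon, 2 nitrogen, 1 oxygen; no ring), on a saturated chain carbon, three bonds along the chain from an aromatic nitrogen. For the measured compounds named here, no measured step bears on this change; the step from compound 2 to compound 3 is unreadable, and nothing among the three compounds distinguishes one chain end from another on this read-out. The expectation is that compound 4 sits where the others sit, at or past the limit, with no step beyond the scatter readable in this assay; the estimated step is a step that the limit leaves unreadable from compound 1 to compound 4. The estimate for compound 4 is 80000 nM, in the range 30000 nM to 300000 nM.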

Compound 4, half-maximal cytotoxic concentration: > 50000 nM
Compound 4: no number, only a limit; the forecaster's own chance of this, stated with the estimate: 85%; the middle value does not contradict the limit.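

No step can be read from compound 1 to compound 4, since both values are limits in this assay: the limit of > 50000 nM in this assay, at which 4 of the 4 values shown sit.

The compounds shown leave open at what concentration any of them would give an actual number on this read-out, and whether trifluoromethyl and the other chain ends differ at all.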